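A Second Hydroxymethyl on the Shared Core

A few compounds are considered here, and "the series" means these few. Any claim that something is new, unique, unknown or untested is made for them only; others in the source may bear on it.

Compound 1, `Cc1c(CO)cc2n1[C@@H](c1ccccc1)SC2`, gives 4300 nM in a functional assay on MCF7 cells (Homo sapiens) for cytotoxicity, read by MTT assay, with a stated time of 48 h; a lower number here means a stronger inhibitor, a higher number a weaker inhibitor.
Compound 2, `Cc1c(COC(=O)NCc2ccccc2)cc2n1[C@@H](c1ccccc1)SC2`, gives 4400 nM in this assay.

These two numbers sit within the usual scatter of each other, so compound 1 stands level with compound 2 and neither can be set apart. Compound 3, `Cc1c(CO)c(CO)c2n1[C@@H](c1ccccc1)SC2`, differs from compound 1 by hydroxymethyl in place of hydrogen on an aromatic carbon. For the measured compounds named here, no pair among the measured compounds shows what this kind of change does, so the expectation rests only on the small spread seen so far: no step beyond the scatter in this assay. Compound 3 is therefore expected to give about 4500 nM, between 2000 nM and 10000 nM, an expected step of a 1.0-fold higher number from compound 1 to compound 3 (0.02 log units; within the scatter) that stays within the scatter.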

Compound 3, half-maximal inhibitory concentration: 1900 nM
Estimate against measurement, compound 3: 2.4-fold (0.37 log units) above; measured number below the stated range.
By their numbers in this assay, from the lowest: compound 3; then compounds 1 and 2 (each within the scatter of the next).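

For the compounds shown here, in the earlier compounds this aromatic carbon carried only hydrogen, so they could not show whether the position matters. In this assay hydroxymethyl in place of that hydrogen gives a 2.3-fold lower number from compound 1 to compound 3 (0.35 log units; beyond the scatter) and so shows that a small group here can change the number, though only modestly. No measurement shown explains why this happens.

Only this one group is shown on this carbon, so it remains open whether the oxygen matters or any added group would do. A plain methyl, an amine or a carboxylic acid on the same aromatic carbon would help to separate these possibilities.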